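Swapping a Lactam Ring for a Methylimidazole at EP3

A few compounds are considered here, and "the series" means these few. Any claim that something is new, unique, unknown or untested is made for them only; others in the source may bear on it.

Of the compounds shown here, three sharing one core have been tested in an assay on CHO cells for displacement of a labelled ligand from prostaglandin E2 receptor EP3 subtype (Homo sapiens), read by radioligand binding; on this read-out lower numbers stand for stronger inhibition and higher numbers for weaker inhibition. Compound 1 `CC(C)C(c1nnc[nH]1)c1ccc(-c2ccc3cccc(F)c3c2)[nH]c1=O` gives 12 nM, and compound 2 `CC(C)C(Cc1ncc[nH]1)c1ccc(-c2ccc3cccc(F)c3c2)[nH]c1=O` gives 11 nM; the step of a 1.1-fold lower number from compound 1 to compound 2 (0.04 log units; within the scatter) lies within the scatter. Compound 3 `CC(C)C(/C=C1/CCNC1=O)c1ccc(-c2ccc3cccc(F)c3c2)[nH]c1=O` gives 5.3 nM and stands lowest of the three: the steps of a 2.3-fold lower number from compound 1 to compound 3 (0.35 log units; beyond the scatter) and a 2.1-fold lower number from compound 2 to compound 3 (0.32 log units; beyond the scatter) are both modest but beyond the scatter.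

Compound 4 `Cc1c[nH]c(C(c2ccc(-c3ccc4cccc(F)c4c3)[nH]c2=O)C(C)C)n1` is not yet measured. It differs from compound 3 in one place: a group of 6 heavy atoms (4 carbon, 2 nitrogen; one five-membered aromatic ring with 2 hetero atoms) in place of a group of 7 heavy atoms (5 carbon, 1 nitrogen, 1 oxygen; one five-membered non-aromatic ring with 1 hetero atom), on a saturated chain carbon bound to an aromatic carbon and a saturated chain carbon

The two steps that end at compound 3 bear on this change in reverse. Each time the five-membered non-aromatic ring of compound 3 was compared with a five-membered aromatic ring of compound 1 or compound 2, the aromatic ring gave a modestly higher number. Compound 4 carries such an aromatic ring again, so a modest rise is expected, roughly undoing those steps, as a 2.1-fold higher number from compound 3 to compound 4 (0.32 log units; beyond the scatter). Compound 4 is therefore estimated at 11 nM, with a likely range from 5 nM to 25 nM.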

Compound 4, inhibition constant: 12 nM
Beside the measured number, compound 4's estimate is 1.1-fold (0.04 log units) below it; the range from low to high includes it.
By their numbers in this assay, from the lowest: compound 3; then compounds 2, 1 and 4 (each within the scatter of the next).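

In this assay, putting 4-methyl-1H-imidazol-2-yl on this saturated chain carbon in place of the five-membered non-aromatic ring gives a 2.3-fold higher number from compound 3 to compound 4 (0.35 log units; beyond the scatter), a modest step, so each of the three five-membered aromatic rings shown now gives a higher number than the non-aromatic ring of compound 3. The aromatic groups themselves cannot be told apart in this set: a 1.1-fold higher number from compound 2 to compound 4 (0.04 log units; within the scatter) and no change at the digits printed from compound 1 to compound 4 (within the scatter) are both small enough to be scatter, whether the group is 4-methyl-1H-imidazol-2-yl, (1H-imidazol-2-yl)methyl or 4H-1,2,4-triazol-3-yl.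

On these data alone, whether an amine, a carboxylic acid or a longer chain on this carbon would match compound 3 remains open. Nothing given here explains why the non-aromatic ring gives the lowest number.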